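The source may hold more compounds than are shown below. What is called first, only, known or untested is meant among the compounds shown, and "the series" means these compounds.

Compound 1 `O=c1c(C2N=C(c3ccccc3)SS2)coc2ccc(F)cc12` gives in a functional assay on PC-3 cells (Homo sapiens) for inhibition, read by sulforhodamine B assay, with a stated time of 48 h (a higher number here means a weaker inhibitor, a lower number a stronger inhibitor), only the limit > 100000 nM.
Compound 2 `O=c1c(C2N=C(c3ccccc3)SS2)coc2ccccc12` gives in this assay only the limit > 100000 nM.
For the measured compounds named here, compound 3 `O=c1c(C(=S)Nc2ccccc2)coc2ccccc12` gives in this assay the one actual number of the set, 60600 nM.

Compound 1 and compound 2 share one core, compound 3 has another; how the two cores differ is not broken down here. Within the first core the change from compound 2 to compound 1 is fluoro in place of hydrogen on an aromatic carbon. Its size in this assay cannot be read, a step that the two limits leave unreadable from compound 2 to compound 1, because both compounds sit at the limit of > 100000 nM in this assay, at which 2 of the 3 values shown sit.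

Compound 4 `O=c1c(C(=S)Nc2ccccc2)coc2ccc(F)cc12` has not yet been measured. It stands to compound 3 as compound 1 stands to compound 2: fluoro in place of hydrogen on an aromatic carbon. The place of the change reads the same in both pairs, so it is the same change on a different core.

Since the measured pair gives no readable size, the expectation for compound 4 rests on compound 3 alone and on the change being small in atoms. Compound 4 is expected to stay close to compound 3, with a step of a 1.0-fold lower number from compound 3 to compound 4 (0.00 log units; within the scatter). The estimate for compound 4 in this assay is 60000 nM, between 25000 nM and 150000 nM.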

Compound 4, half-maximal inhibitory concentration: > 100000 nM
Compound 4: only a limit was reported; the forecaster's own chance of this, stated with the estimate: 30%; middle value at least 1.6-fold (0.22 log units) away from the limit.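

On the core of compound 3, fluoro in place of hydrogen on an aromatic carbon gives an at least 1.6-fold higher number from compound 3 to compound 4 (0.21 log units; that floor lies within the scatter); compound 4 carries only a limit, so this size is a floor, and the true step may be larger or may not stand out from the scatter at all. On the core of compound 1 and compound 2, the size of the same change cannot be read, because both compounds sit at a limit: the limit of > 100000 nM in this assay, at which 3 of the 4 values shown sit. For the compounds shown here, the two cores therefore offer no pair of sizes to compare, and nothing here shows whether the change carries over from one core to the other with a similar size.

As far as these compounds go, only hydrogen and fluoro appear at this place, so the effect of chloro, methoxy or an amine there remains open. From the compounds shown here alone, it also remains open how either core would read with a carboxylic acid or a longer chain in this assay.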